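Cyano for fluoro: what the measured steps foretell

The source may report more compounds than this note shows. Statements on the series, on what has been measured and on what is new or still open speak of the compounds shown alone.

Compound 1, `O=C(Nc1ccc2cc[nH]c2c1)c1ccc(Br)cc1`, gives 63700 nM in a functional assay on T47D cells (Homo sapiens) for antiproliferative activity, read by MTT assay, with a stated time of 24 h; on this read-out lower numbers stand for stronger inhibition and higher numbers for weaker inhibition.
Compound 2, `Cc1ccc(S(=O)(=O)Nc2ccc3cc[nH]c3c2)cc1`, gives 57100 nM in this assay.
Compound 3, `O=C(Nc1ccc2cc[nH]c2c1)c1ccc(F)cc1`, gives 35100 nM in this assay.

Among the measured compounds shown here, compound 3 carries the lowest of the three numbers, yet its distances to compound 2 and to compound 1 both lie within the scatter, so no compound here can be called the most active. Compound 4, `N#Cc1ccc(C(=O)Nc2ccc3cc[nH]c3c2)cc1`, differs from compound 3 in one place: cyano in place of fluoro on an aromatic carbon. For the measured compounds named here, the only measured one-place step, a 1.8-fold lower number from compound 1 to compound 3 (0.26 log units; within the scatter), exchanged one halogen for another and stayed within the scatter. Going by the values given here, no measured step exchanges a halogen for cyano, so the data give no further guide. Compound 4 is therefore expected to stay close to compound 3, with an estimated step of a 1.0-fold lower number from compound 3 to compound 4 (0.00 log units; within the scatter). The estimate for compound 4 in this assay is 35000 nM, between 12000 nM and 100000 nM.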

Compound 4, half-maximal inhibitory concentration: 35800 nM
Compound 4: the middle estimate sits 1.0-fold (0.01 log units) below what was measured; measured number inside the range.
By their numbers in this assay, from the lowest: compounds 3, 4, 2 and 1 (each within the scatter of the next).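

Among the compounds shown here, at the aromatic carbon para to a large group, the earlier compounds showed only one halogen exchanged for another; in this assay the exchange for cyano, which brings a triple bond and a hydrogen-bond acceptor, gives a 1.0-fold higher number from compound 3 to compound 4 (0.01 log units; within the scatter) and, measured against bromo, gives a 1.8-fold lower number from compound 1 to compound 4 (0.25 log units; within the scatter). Both steps lie within the scatter, so bromo, fluoro and cyano cannot be told apart at this position. Nothing available accounts for this result.

The compounds shown leave open whether an amine, a carboxylic acid or a longer chain on this carbon would shift the number beyond the scatter. They also leave open whether any of these groups would matter elsewhere on the ring.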